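This account rests on a few compounds, and the source may have more. Where it says the series, first, only, none or still open, it means among the compounds named here.

Measured in a functional assay on MDA-MB-231 cells (Homo sapiens) for inhibition, read by MTT assay, with a stated time of 48 h; a higher number here means a weaker inhibitor, a lower number a stronger inhibitor:
- compound 1 `COc1cc(-c2nccn3cc(-c4ccc5[nH]ccc5c4)nc23)cc(OC)c1OC`: 74 nM
- compound 2 `COc1cc(-c2nccn3cc(-c4ccc(C(F)(F)F)cc4)nc23)cc(OC)c1OC`: > 10000 nM (a limit of the assay, not a number)
- compound 3 `COc1cc(-c2nccn3cc(-c4ccc(N)cc4)nc23)cc(OC)c1OC`: 294 nM

Of the two numeric values, the higher belongs to compound 3, at 294 nM. Compound 1 is the nearest neighbour, with a 4.0-fold higher number from compound 1 to compound 3 (0.60 log units; beyond the scatter), a modest step beyond the scatter.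

Next in the series is compound 4 `COc1cc(-c2nccn3cc(-c4ccc(C)cc4)nc23)cc(OC)c1OC`, with methyl in place of amino on an aromatic carbon, para to a large group (methyl in place of amino on an aromatic carbon).

For the measured compounds named here, no methyl compound has been measured, so the evidence is indirect. The closest step is an at least 34-fold lower number from compound 2 to compound 3 (1.53 log units; beyond the scatter), which is large and also changes the group at this place, with amino entering in place of trifluoromethyl. Replacing the indolyl group of compound 1 shows the same contrast, with an at least 130-fold higher number from compound 1 to compound 2 (2.13 log units; beyond the scatter) being large and a 4.0-fold higher number from compound 1 to compound 3 (0.60 log units; beyond the scatter) only modest. Amino is thus the better tolerated of the two groups measured here. Losing it in compound 4 should raise the number, though probably by less than the full step seen with trifluoromethyl.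

The expected step is a 5.1-fold higher number from compound 3 to compound 4 (0.71 log units; beyond the scatter), toward weaker inhibition in this assay. For compound 4 the estimated value is 1500 nM, with an expected range of 400 nM to 8000 nM.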

Compound 4, half-maximal inhibitory concentration: 53 nM
For compound 4 the middle estimate is 28-fold (1.45 log units) above the measured one; the measured number lies below the stated range.
By their numbers in this assay, from the lowest: compounds 4 and 1 (each within the scatter of the next); then compound 3. At a limit, above all of these: compound 2.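

In this assay, a hydrogen-bond donor and acceptor on the para substituent are not needed for activity: methyl in place of amino gives a 5.5-fold lower number from compound 3 to compound 4 (0.74 log units; beyond the scatter), while the simple 4-methylphenyl group cannot be told apart from the 1H-indol-5-yl group, with a 1.4-fold lower number from compound 1 to compound 4 (0.14 log units; within the scatter). The sharpest contrast at this position now lies between methyl and trifluoromethyl, which share a single attachment carbon yet give an at least 180-fold lower number from compound 2 to compound 4 (2.27 log units; beyond the scatter). Compound 2 stands at a limit of the assay, so that step gives only a bound and not its full size: the limit of > 10000 nM in this assay, at which 1 of the 4 values shown sits.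

The compounds shown leave open how far activity holds as the para group changes beyond these few, for example with a chlorine, a methoxy group or a longer chain such as ethyl. They also leave open whether the gap between methyl and trifluoromethyl arises gradually, which a fluoromethyl or difluoromethyl group at the same place would help to resolve.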